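The source may hold more compounds than are shown below. What is called first, only, known or untested is meant among the compounds shown, and "the series" means these compounds.

Compound 1 `Cc1cc(C)c(NC(=O)c2sccc2S(=O)(=O)Nc2onc(C)c2Cl)c(C)c1CO` was tested in an in vivo ADME assay on the whole organism (plasma) for pharmacokinetics, with Rattus norvegicus as the target, at a dose of 50 mg/kg by the oral route (a lower number here means less compound in the circulation, a higher number more compound in the circulation at the dose given), where compound 1 gives 5110 nM. Compound 2 `CC(=O)OCc1c(C)cc(C)c(NC(=O)c2sccc2S(=O)(=O)Nc2onc(C)c2Cl)c1C` carries an acetyl in place of hydrogen on an oxygen on a saturated carbon, and in this assay compound 2 gives 7420 nM. Among the measured compounds shown here, the step of a 1.5-fold higher number from compound 1 to compound 2 (0.16 log units; within the scatter) is the only measured step so far. For the measured compounds named here, of the two numbers known, compound 2 sits within the scatter of compound 1, so these two values tell nothing apart.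

Compound 3 `Cc1cc(C)c(N(C)C)c(C)c1NC(=O)c1sccc1S(=O)(=O)Nc1onc(C)c1Cl` has not been measured. Relative to compound 2 it differs by dimethylamino in place of acetoxymethyl on an aromatic carbon. Going by the values given here, the single step of a 1.5-fold higher number from compound 1 to compound 2 (0.16 log units; within the scatter) touched the same part of the molecule but exchanged only hydrogen for acetyl on that oxygen; nothing measured shows what removing the whole acetoxymethyl and bringing in dimethylamino does. With no measured step beyond the scatter, the expectation for compound 3 in this assay is a change a 1.2-fold lower number from compound 2 to compound 3 (0.09 log units; within the scatter) that stays within the scatter. Compound 3 is therefore estimated at 6000 nM, with a range from 2500 nM to 15000 nM.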

Compound 3, maximal plasma concentration: 6620 nM
Compound 3: the middle estimate sits 1.1-fold (0.04 log units) below what was measured; the range from low to high includes it.
By their numbers in this assay, from the lowest: compounds 1, 3 and 2 (each within the scatter of the next).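

In this assay, replacing the whole side group on this aromatic carbon, rather than only capping its oxygen, gives a 1.1-fold lower number from compound 2 to compound 3 (0.05 log units; within the scatter), and the smaller dimethylamino thus stands in for the larger acetoxymethyl without a change that can be told from the scatter. The comparison with the free alcohol agrees, with a 1.3-fold higher number from compound 1 to compound 3 (0.11 log units; within the scatter), so hydroxymethyl, acetoxymethyl and dimethylamino, which join the ring through different atoms and differ in size, all give values that cannot be separated at this place, ortho to two methyl groups and para to a methyl group. Nothing available explains why these three groups read alike, and this single read-out of peak plasma level does not show how much of each compound circulates over time.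

As far as these compounds go, it remains open whether a carboxylic acid, a primary amine or a longer chain on this aromatic carbon would move the number beyond the scatter. From the compounds shown here alone, it is also open whether plain hydrogen there would do so, which would show if the position needs any such group at all.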